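This account rests on a few compounds, and the source may have more. Where it says the series, first, only, none or still open, it means among the compounds named here.

Measured so far, in a functional assay on MCF7 cells (Homo sapiens) for inhibition, read by sulforhodamine B assay, with a stated time of 48 h; a lower number here means a stronger inhibitor of growth, a higher number a weaker inhibitor of growth:

compound 1 `COc1ccc(/C=C/C2CC(=O)C=CO2)cc1OC`: 130 uM
compound 2 `COc1cc(/C=C/C2CC(=O)C=CO2)cc(OC)c1OC`: 149 uM
compound 3 `COc1ccc(/C=C/c2cc(=O)cco2)cc1`: 396 uM

Compound 2 carries one methoxy more than compound 1, and a 1.1-fold higher number from compound 1 to compound 2 (0.06 log units; within the scatter). Compound 3 rests on a different core; the difference between the two cores is not broken down here. Against its nearest neighbour, compound 2, compound 3 gives the higher number, beyond the scatter, and the same holds against compound 1.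

Compound 4, `COc1ccc(/C=C/c2cc(=O)cco2)cc1OC`, is still to be measured in this assay. It arises from compound 3 by methoxy in place of hydrogen on an aromatic carbon. Compound 2 arises from compound 1 by methoxy in place of hydrogen on an aromatic carbon. The two changes are of the same kind, not the same: in compound 1 the place is also meta to a methoxy group (2 heavy atoms), which is not so in compound 3.

For the measured compounds named here, the only precedent for the change is a 1.1-fold higher number from compound 1 to compound 2 (0.06 log units; within the scatter), so little movement is expected; the step from compound 3 to compound 4 is estimated as a 1.1-fold higher number from compound 3 to compound 4 (0.03 log units; within the scatter). Compound 4 is expected near 420 uM in this assay, plausibly between 250 uM and 700 uM.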

Compound 4, concentration for growth inhibition (reported as GI): 954 uM
Beside the measured number, compound 4's estimate is 2.3-fold (0.36 log units) below it, and the stated range ends below it.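

In this assay, methoxy in place of hydrogen on an aromatic carbon gives a 2.4-fold higher number from compound 3 to compound 4 (0.38 log units; beyond the scatter), a modest loss of growth inhibition on that core, while the same kind of change on the other core gives a 1.1-fold higher number from compound 1 to compound 2 (0.06 log units; within the scatter). Read alone, the two steps look unlike, but set side by side they do not separate, so nothing here shows that the two cores respond differently to this change: the same change on two cores in this assay, a 1.1-fold higher number (0.06 log units; within the scatter) from compound 1 to compound 2 and a 2.4-fold higher number (0.38 log units; beyond the scatter) from compound 3 to compound 4, 2.1-fold (0.32 log units) apart, within the scatter of two such steps. Nor do the data fix a transferable size for the step, as each core offers a single pair and the added methoxy does not have the same surroundings in both pairs.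

Open, from the compounds shown here alone, is whether a hydroxy group, a chlorine atom or an amine at the same place would follow the same course on either core. Also open, going by these compounds, is whether a longer chain such as ethoxy would push the number further up, or whether any group on this aromatic ring would bring it down.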